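Swapping an Aryl Group in a Cytotoxicity Series

A few compounds are considered here, and "the series" means these few. Any claim that something is new, unique, unknown or untested is made for them only; others in the source may bear on it.

The measured compounds:
- compound 1, `CN(c1cc2ncc(=O)[nH]c2cc1NC(=S)NC(=O)c1cccc2ccccc12)C1CCCCC1`, gives 9980 nM in an ADME assay on Huh-7 cells (Homo sapiens) for cytotoxicity; on this read-out lower numbers stand for stronger inhibition and higher numbers for weaker inhibition
- compound 2, `CN(c1cc2ncc(=O)[nH]c2cc1NC(=S)NC(=O)c1ccco1)C1CCCCC1`, gives 17300 nM in this assay
- compound 3, `CN(c1cc2ncc(=O)[nH]c2cc1Nc1nc(-c2ccc(Cl)cc2)cs1)C1CCCCC1`, gives 16700 nM in this assay

Among these three, compound 3 has the second highest number. Its nearest neighbour is compound 2, whose number is within the scatter of that of compound 3, and its furthest neighbour is compound 1, which also stays within the scatter. The three measured values therefore do not separate from each other.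

Compound 4, `CN(c1cc2ncc(=O)[nH]c2cc1Nc1nc(-c2cccc3ccccc23)cs1)C1CCCCC1`, differs from compound 3 in one place: naphthalen-1-yl in place of 4-chlorophenyl on an aromatic carbon. For the measured compounds named here, the only measured step that bears on this change is the one from compound 1 to compound 2, which also exchanges one aromatic group for another, there with furan-2-yl taking the place of naphthalen-1-yl; that step was a 1.7-fold higher number from compound 1 to compound 2 (0.24 log units; within the scatter). An aryl swap of this kind thus left the number essentially where it was, and compound 4 is expected to behave likewise, with no step beyond the scatter in this assay in either direction.

The step from compound 3 to compound 4 is accordingly estimated at a 1.3-fold lower number from compound 3 to compound 4 (0.11 log units; within the scatter). Compound 4 is expected to give about 13000 nM, within a range from 5500 nM to 31000 nM.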

Compound 4, half-maximal inhibitory concentration: 57400 nM
Compound 4: the middle estimate sits 4.4-fold (0.64 log units) below what was measured; the whole stated range lies below it.
By their numbers in this assay, from the lowest: compounds 1, 3 and 2 (each within the scatter of the next); then compound 4.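

At this position, on an aromatic carbon of the five-membered aromatic ring with 1 nitrogen and 1 sulfur, the choice of aryl group does register in this assay: naphthalen-1-yl in place of 4-chlorophenyl gives a 3.4-fold higher number from compound 3 to compound 4 (0.54 log units; beyond the scatter). This modest step is the first among the compounds shown to pass beyond the scatter, whereas the earlier exchange of aromatic groups, made on a carbonyl carbon, gives a 1.7-fold higher number from compound 1 to compound 2 (0.24 log units; within the scatter) and stays within it, so a result at one place did not carry over to the other. Nothing available accounts for the size or direction of the new step.

The change removes the chlorine and adds a second six-membered aromatic ring at once, and these two compounds cannot show which of the two goes with the higher number; a plain phenyl group at this position would separate them. Also open, from the compounds shown here alone, is how far the number moves with other groups here, such as naphthalen-2-yl, a 4-fluorophenyl or a 4-methoxyphenyl group, or an amine carried on the phenyl ring.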